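Methyl on the ring nitrogen: a step from compound 2

This account rests on a few compounds, and the source may have more. Where it says the series, first, only, none or still open, it means among the compounds named here.

This study concerns an assay on isolated protein for inhibition of Aromatase (Homo sapiens), read by fluorescence, using NADPH, with a stated time of 30 min, tested at 50 uM; a higher number here means more inhibition at the concentration tested (going by the name of the read-out), a lower number less inhibition. Of the compounds shown here, two have been measured. Compound 1, with the structure `Cn1c(-c2ccc(Cl)c(Cl)c2)cc2ccccc21`, gives 20%. Compound 2, with the structure `O=[N+]([O-])c1ccc2[nH]c(-c3ccc(Cl)c(Cl)c3)cc2c1`, gives 7.59%. Compound 2 thus stands lowest of the two numbers, with compound 1 the nearest, a difference beyond the scatter of repeated measurements. Within the data shown here, compound 1 and compound 2 differ in more than one place, so no single step between them is recorded, and their two values show only where each stands.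

The next compound, compound 3, has the structure `Cn1c(-c2ccc(Cl)c(Cl)c2)cc2cc([N+](=O)[O-])ccc21`. It differs from compound 2 in one place: methyl in place of hydrogen on an aromatic nitrogen. The same methyl on the aromatic nitrogen is present in compound 1, which sits higher than compound 2 in this assay, but that comparison is confounded by the other difference between them, so the direction it suggests is uncertain. A small rise or no step beyond the scatter is expected, as a number 4.4 percentage points higher from compound 2 to compound 3 (within the scatter). Compound 3 is therefore estimated to give 12%, within a range from 2% to 25%.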

Compound 3, a percentage reported as inhibition, at one concentration (the size of the read-out at that concentration, not a potency): 34%
Estimate against measurement, compound 3: 22 percentage points below, and the stated range ends below it.
By their numbers in this assay, from the lowest: compound 2; then compound 1; then compound 3.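

Methyl in place of hydrogen on the aromatic nitrogen gives a number 26.4 percentage points higher from compound 2 to compound 3 (beyond the scatter) in this assay, so in this pair the hydrogen on that nitrogen is not needed for the inhibition seen, and the methyl goes with a higher number. Nitro in place of hydrogen on an aromatic carbon, with the methyl already on the nitrogen, gives a number 14 percentage points higher from compound 1 to compound 3 (beyond the scatter) in the same test, so the nitro group of compound 2, which has the lowest number of the set, goes with a rise once the methyl is present. Compound 3 carries both groups and stands above compound 1 and compound 2, with both steps beyond the scatter, although each number is a single reading at one concentration and not a potency.

On these data alone, the step from hydrogen to methyl is known here only with the nitro group in place, and it remains open whether a longer chain such as ethyl on the nitrogen, or an amine or a carboxylic acid in place of the nitro, would raise the number further. No measurement among these compounds explains either rise.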